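This account rests on a few compounds, and the source may have more. Where it says the series, first, only, none or still open, it means among the compounds named here.

Measured compounds

Compound 1, `Cn1nc(N)c2c(=O)[nH]c(-c3ccccc3)cc21`, gives 4% in an assay on isolated protein for inhibition of RAC-beta serine/threonine-protein kinase (Homo sapiens), read by mobility shift assay, tested at 30 uM; on this read-out lower numbers stand for less inhibition and higher numbers for more inhibition at the one concentration tested (going by the name of the read-out).
Compound 2, `Cn1nc(N)c2c(=O)[nH]c(-c3ccccn3)cc21`, gives 10% in this assay.
Compound 3, `Nc1c2c(=O)[nH]c(-c3ccccc3)cc2nn1-c1ccccc1`, gives -1% in this assay.

All three compounds share a core carrying an amino group and an aryl group, and all three show only small inhibition in this assay. Compound 1 and compound 2 differ in one place, (pyridin-2-yl in place of phenyl on an aromatic carbon), and this change gave a number 6 percentage points higher from compound 1 to compound 2 (within the scatter). Compound 3 carries a phenyl on the ring nitrogen where compound 1 carries a methyl; the difference between the two cores is not broken down here. The value of compound 3 sits close to that of compound 1, and both are far from any strong inhibition.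

Compound 4, `Nc1c2c(=O)[nH]c(-c3ccccn3)cc2nn1-c1ccccc1`, has not yet been measured. It differs from compound 3 in the same way that compound 2 differs from compound 1: pyridin-2-yl in place of phenyl on an aromatic carbon. The place of the change is described in the same words for both pairs, so it is the same change on a core that differs only in the group on the ring nitrogen.

The expected size of the step is a number 6 percentage points higher from compound 3 to compound 4 (within the scatter). This expectation rests on compound 1 and compound 2, whose step is a number 6 percentage points higher from compound 1 to compound 2 (within the scatter), a step that lies within the usual scatter of this assay. Compound 4 is therefore estimated to give 5%, with a likely range from -5% to 15%.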

Compound 4, a percentage reported as inhibition, at one concentration (the size of the read-out at that concentration, not a potency): 8%
Estimate against measurement, compound 4: 3 percentage points below; the measured number falls inside the stated range.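

Pyridin-2-yl in place of phenyl on an aromatic carbon, carried over to the core with a phenyl on the ring nitrogen, gave a number 9 percentage points higher from compound 3 to compound 4 (within the scatter) in this assay. Set beside the earlier step on the core with a methyl on the ring nitrogen, the change reads alike on both cores: the same change on two cores in this assay, a number 6 percentage points higher (within the scatter) from compound 1 to compound 2 and a number 9 percentage points higher (within the scatter) from compound 3 to compound 4, 3 percentage points apart, within the scatter of two such steps. This shows that, on these two cores, the change gives steps that cannot be told apart, but it does not show that the change has a real effect on either core, as each step lies within the scatter and all four compounds show only small inhibition at the one concentration tested.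

The compounds shown leave open whether a group other than methyl or phenyl on the ring nitrogen, such as a longer chain or a benzyl, would give a step beyond the scatter. They also leave open what an amide in place of the amino group, or a carboxylic acid or an amine on the phenyl or pyridin-2-yl, would give on either core.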